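Succinate receptor 1 antagonists: chloro to trifluoromethyl exchange

This account rests on a few compounds, and the source may have more. Where it says the series, first, only, none or still open, it means among the compounds named here.

Measured in a functional assay on CHO-K1 cells for antagonist activity at succinate receptor 1 (Homo sapiens), read by FLIPR and calcium flux; on this read-out lower numbers stand for stronger inhibition and higher numbers for weaker inhibition:
Compound 1, `CCc1cccc(-c2ccc(CNC(=O)CCCc3ccc4cccnc4n3)cc2)c1`, gives 65 nM.
Compound 2, `O=C(CCCc1ccc2cccnc2n1)NCc1cc(-c2cccc(Cl)c2)no1`, gives 65 nM.
Compound 3, `O=C(CCCc1ccc2cccnc2n1)NCc1cc(-c2ccc(F)c(Cl)c2)no1`, gives 90 nM.

Compound 3 sits alongside compound 1 and compound 2 in this assay: its gaps to both lie within the scatter, so the three numbers are not separated. Going by the values given here, the one single-point step recorded so far is a 1.4-fold higher number from compound 2 to compound 3 (0.14 log units; within the scatter), a fluoro entering on an aromatic carbon, and it did not move the number beyond the scatter.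

Compound 4, `O=C(CCCc1ccc2cccnc2n1)NCc1cc(-c2ccc(F)c(C(F)(F)F)c2)no1`, has not yet been measured. Relative to compound 3 the change is trifluoromethyl in place of chloro on an aromatic carbon. Among the compounds with values here, no measured pair shows a chloro leaving or a trifluoromethyl entering, so no step bears directly on this exchange; the only neighbouring step, a 1.4-fold higher number from compound 2 to compound 3 (0.14 log units; within the scatter), touched the same ring and stayed within the scatter. In this assay the number for compound 4 is therefore expected to stay close to that of compound 3, the expected step being a 1.1-fold higher number from compound 3 to compound 4 (0.05 log units; within the scatter), not beyond the scatter in either direction. The estimate for compound 4 in this assay is 100 nM, with a range from 40 nM to 300 nM.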

Compound 4, half-maximal inhibitory concentration: 35 nM
Estimate against measurement, compound 4: 2.9-fold (0.46 log units) above, and the stated range ends above it.
By their numbers in this assay, from the lowest: compounds 4, 1, 2 and 3 (each within the scatter of the next, the first and the last beyond it).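

In this assay, trifluoromethyl in place of chloro, on an aromatic carbon ortho to a fluoro group, gives a 2.6-fold lower number from compound 3 to compound 4 (0.41 log units; beyond the scatter), the only step shown that lies beyond the scatter, so the number does respond to the group at this position, and four heavy atoms are tolerated there where one stood. The wider change, with a 1.9-fold lower number from compound 2 to compound 4 (0.27 log units; within the scatter), does not separate its pair, so the trifluoromethyl compound stands clear only of its 3-chloro-4-fluorophenyl partner and the effect remains modest across the set. Nothing available here accounts for the size or direction of the exchange.

The compounds shown leave open whether trifluoromethyl would read the same with hydrogen in place of the fluoro group, and whether a nitrile, a methoxy group or a tert-butyl group on this carbon would keep or lose the number of compound 4. Also open, from the compounds shown here alone, is whether a trifluoromethyl group on the core of compound 1 would read alike.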